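The compounds below may be only part of what the source reports. "The series", "measured", "known", "first", "only" and "open" are said of these compounds alone.

Measured so far in a functional assay on MCF7 cells (Homo sapiens) for inhibition, read by sulforhodamine B assay, with a stated time of 72 h; a lower number here means a stronger inhibitor of growth, a higher number a weaker inhibitor of growth:
Compound 1, `O=C(O)/C=C/c1ccncc1-c1ccc2cc[nH]c2c1`, gives > 10000 nM, which is a limit of the assay and not a number.
Compound 2, `NC(=O)/C=C/c1ccncc1-c1ccc2ccccc2c1`, gives > 10000 nM, likewise a limit of the assay rather than a number.

Compound 2 therefore stands at a limit only: both values shown sit at the same upper limit, and nothing in the numbers separates it from compound 1. What is known of this set is summed up as the limit of > 10000 nM in this assay, at which 2 of the 2 values shown sit. The step under consideration leads from compound 2 to compound 3, `O=C(O)/C=C/c1ccncc1-c1ccc2ccccc2c1`, which still awaits measurement in this assay . The change is hydroxy in place of amino on a carbonyl carbon. Within the data shown here, no step between measured compounds is available to scale this change. Among the measured compounds shown here, the one comparison in hand is that compound 1, which also carries the carboxy group, returns > 10000 nM, itself a limit. For compound 3 the expected step is a step that the limit leaves unreadable from compound 2 to compound 3, nothing beyond the scatter. Compound 3 is accordingly estimated at 15000 nM, within 5000 nM to 50000 nM, and most probably reported once more only as a limit.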

Compound 3, concentration for 50% growth inhibition: > 10000 nM
Compound 3 ended at the assay's limit; the forecaster's own chance of this, stated with the estimate: 80%; the middle value does not contradict the limit.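

Compound 2 and compound 3 both end at a limit of the assay, so no step can be read for hydroxy in place of amino on a carbonyl carbon. The set so far comes down to one result: the limit of > 10000 nM in this assay, at which 3 of the 3 values shown sit. The compounds shown leave open what change, if any, would bring a readable value in this assay.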